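Notes on replacing iodo with ethoxy

The source may report more compounds than this note shows. Statements on the series, on what has been measured and on what is new or still open speak of the compounds shown alone.

In a functional assay on FM3A cells (Mus musculus) for antiproliferative activity, with a stated time of 48 h (a lower number here means a stronger inhibitor, a higher number a weaker inhibitor), compound 1 `Nc1ccc(/C=C/C(=O)c2ccccc2)cc1` gives 146000 nM, compound 2 `Nc1ccc(/C=C/C(=O)c2ccc(Cl)cc2)cc1` gives 178000 nM and compound 3 `Nc1ccc(/C=C/C(=O)c2ccc(I)cc2)cc1` gives 110000 nM. These three values lie within the scatter of each other, so compound 3 holds no separate place among them.

The next structure is compound 4 `CCOc1ccc(C(=O)/C=C/c2ccc(N)cc2)cc1`, with ethoxy in place of iodo on an aromatic carbon, para to a large group: ethoxy in place of iodo on an aromatic carbon.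

Within the data shown here, three measured steps bear on this change, all made on that same aromatic carbon. They are a 1.2-fold higher number from compound 1 to compound 2 (0.09 log units; within the scatter), a 1.3-fold lower number from compound 1 to compound 3 (0.12 log units; within the scatter) and a 1.6-fold lower number from compound 2 to compound 3 (0.21 log units; within the scatter). Each stays within the scatter, so hydrogen, chloro and iodo cannot be told apart here. Among the measured compounds shown here, none of these steps brings in ethoxy, and the series holds no other measured compound with an oxygen on that carbon, so the expectation rests on an extrapolation from these three compounds alone.

No step beyond the scatter is expected in this assay, and the estimate is a 1.1-fold higher number from compound 3 to compound 4 (0.06 log units; within the scatter). For compound 4 the expected value is 125000 nM, with an estimated range from 60000 nM to 250000 nM.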

Compound 4, half-maximal inhibitory concentration: 55000 nM
Compound 4: middle estimate off by 2.3-fold (0.36 log units), on the high side, outside the stated range (below it).
By their numbers in this assay, from the lowest: compounds 4, 3, 1 and 2 (each within the scatter of the next, the first and the last beyond it).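

In this assay, among these compounds, ethoxy is the first group on this aromatic carbon to separate from others, with a 3.2-fold lower number from compound 2 to compound 4 (0.51 log units; beyond the scatter) and a 2.7-fold lower number from compound 1 to compound 4 (0.42 log units; beyond the scatter), both modest but beyond the scatter, whereas hydrogen, chloro and iodo could not be told apart. The separation is incomplete, since the step from iodo, a 2.0-fold lower number from compound 3 to compound 4 (0.30 log units; within the scatter), stays within the scatter, so compound 4 stands apart from compound 1 and compound 2 but not from compound 3, and the position responds to substitution only over a narrow span, with compound 4 still at 55000 nM in this assay. No measurement shown here accounts for the difference between ethoxy and the other groups.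

With ethoxy the only oxygen-linked group on this carbon, the compounds shown cannot separate the contribution of the oxygen from that of the two-carbon chain beyond it. Methoxy, hydroxy and a longer chain such as butoxy would address that question, and an amine or a carboxylic acid at the same place would show whether the trend extends beyond the groups seen so far.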